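Methoxyphenyl for ethoxyphenyl on the amide nitrogen

This account rests on a few compounds, and the source may have more. Where it says the series, first, only, none or still open, it means among the compounds named here.

Compound 3 `CCOc1ccc(NC(=O)/C=C/c2coc3cc(OC)ccc3c2=O)cc1` carries a 4-ethoxyphenyl on its amide nitrogen. In a functional assay on HeLa cells (Homo sapiens) for inhibition, read by MTT assay, with a stated time of 48 h (on this read-out lower numbers stand for stronger inhibition and higher numbers for weaker inhibition), compound 3 gives only a limit, > 100000 nM, so its true number is not known. Its neighbours are measured: compound 1 `COc1ccc2c(=O)c(/C=C/C(=O)Nc3ccc(C)cc3)coc2c1`, with 4-methylphenyl in the same place, gives 24100 nM in this assay, and compound 2 `COc1ccc2c(=O)c(/C=C/C(=O)NCc3ccccc3)coc2c1`, with benzyl there, gives 33400 nM. Between these two the step is a 1.4-fold higher number from compound 1 to compound 2 (0.14 log units; within the scatter). Moving to compound 3 costs more: an at least 4.1-fold higher number from compound 1 to compound 3 (0.61 log units; beyond the scatter) and an at least 2.9-fold higher number from compound 2 to compound 3 (0.47 log units; beyond the scatter), and how much more cannot be seen because of the limit of > 100000 nM in this assay, at which 1 of the 3 values shown sits.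

Compound 4 `COc1ccc2c(=O)c(/C=C/C(=O)Nc3ccccc3OC)coc2c1` differs from compound 3 in one place: 2-methoxyphenyl in place of 4-ethoxyphenyl on an amide-type nitrogen. Both steps into compound 3 went toward weaker inhibition, and compound 4 returns to a group with fewer heavy atoms than the one it replaces, an aryl amide like compound 1. The expectation is therefore a number between that of compound 1 and the limit of compound 3. For compound 4 the expected step is an at least 2.2-fold lower number from compound 3 to compound 4 (0.34 log units; beyond the scatter), toward a lower number. The estimate for compound 4 in this assay is 45000 nM, expected to fall between 15000 nM and 150000 nM.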

Compound 4, half-maximal inhibitory concentration: > 100000 nM
Compound 4: only a limit was reported (the forecaster's own chance of this, stated with the estimate: 35%); at least 2.2-fold (0.34 log units) between middle value and limit.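

In this assay, compound 4 also ends at a limit and not at a number, so 2-methoxyphenyl on the amide-type nitrogen behaves like 4-ethoxyphenyl in giving no measurable value. Among these four compounds, the two whose aromatic ring carries an oxygen-linked group stand at the limit, while the 4-methylphenyl and benzyl compounds give real numbers, and the new compound confirms the loss against both measured neighbours: an at least 2.9-fold higher number from compound 2 to compound 4 (0.47 log units; beyond the scatter), and an at least 4.1-fold higher number from compound 1 to compound 4 (0.61 log units; beyond the scatter). Whether compound 4 is stronger or weaker than compound 3 cannot be read, because both stand at a limit: the limit of > 100000 nM in this assay, at which 2 of the 4 values shown sit.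

The pair also leaves the role of the ring's oxygen-linked group unsettled, as compound 3 and compound 4 differ both in the chain and in the printed ring position, and a 4-methoxyphenyl group would help separate those two changes. On these data alone, it also remains open whether a 4-aminophenyl or 4-carboxyphenyl group on the same nitrogen would give a number in line with compound 1 or another limit.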